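The compounds below may be only part of what the source reports. "The series", "measured", "known", "first", "only" and "open" are said of these compounds alone.

Measured compounds in an assay on membranes from Jurkat cells for displacement of a labelled ligand from Sigma intracellular receptor 2 (Homo sapiens), read by scintillation counting, with a stated time of 1 h; a lower number here means a stronger inhibitor, a higher number a weaker inhibitor:
- compound 1, `Cn1nc(CN2CCCC2)nc1-c1ccc(C2CC2)cc1`: 1000 nM
- compound 2, `Cn1nc(CN2CCCC2)nc1-c1ccc2c(c1)CCC2`: 1000 nM
- compound 3, `Cc1ccc(-c2nc(CN3CCCC3)nn2C)cc1C`: > 1000 nM (a limit of this assay, not a number)

Compound 1 and compound 2 sit level at the digits shown, so the two values are within the scatter of each other and nothing can be said of an order between them. Compound 3 returned only a limit, (the limit of > 1000 nM in this assay, at which 1 of the 3 values shown sits), and so gives no number to set beside the others.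

Compound 4, `Cn1nc(CN2CCCC2)nc1-c1ccc(C(C)(C)C)cc1`, is not yet measured in this assay. It differs from compound 1 in one place: tert-butyl in place of cyclopropyl on an aromatic carbon. Within the data shown here, no step between two measured compounds covers a change of this kind, so there is no recorded pair to read a direction or a size from. Both the group that leaves and the group that enters are small carbon substituents without donors or acceptors, and the rest of the structure is unchanged.

The expectation for the step in this assay is therefore one of no change beyond the scatter, which is what no change at the digits printed from compound 1 to compound 4 (within the scatter) is meant to express. Compound 4 is estimated at 1000 nM, with a range from 400 nM to 2500 nM.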

Compound 4, inhibition constant: > 1000 nM
Compound 4: no number, only a limit (the forecaster's own chance of this, stated with the estimate: 30%); the middle value lies on the limit itself.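

In this assay, compound 4 gives > 1000 nM, a limit of the assay and not a number. Among these compounds, on this aromatic carbon, para to a large group, tert-butyl in place of cyclopropyl gives a number no lower from compound 1 to compound 4 (the limit leaves the size open), so this change shows no gain in binding, which compound 1 and the earlier compounds could not show with no step recorded among them. The series now has little readable room at the weak end of the assay: the limit of > 1000 nM in this assay, at which 2 of the 4 values shown sit.

From the compounds shown here alone, how far compound 4 lies from compound 1 stays open, and so does whether the change has any real effect, since the step may be small enough to vanish in the scatter or much larger. Also open is whether any substituent at this place gives stronger binding than compound 1, as all the groups shown here are plain carbon groups and a group of another kind, such as an amine, a carboxylic acid or a methoxy group, has no value to set against them.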